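Chloro in Place of Hydrogen: Expecting the Cytotoxicity of Compound 4

This account rests on a few compounds, and the source may have more. Where it says the series, first, only, none or still open, it means among the compounds named here.

Measured in a functional assay on T47D cells (Homo sapiens) for cytotoxicity, with a stated time of 72 h, tested at 50 ug/mL; a higher number here means a stronger effect of the compound at the concentration tested, a lower number a weaker effect:
compound 1, `O=c1[nH]nc2n(c1=O)CCN2c1ccccc1`: 0%
compound 2, `Cc1ccc(N2CCN/C2=N\N)cc1`: 17%
compound 3, `N=c1c(=O)[nH]nc2n1CCN2c1ccccc1Cl`: 0%

Compound 1 stands level with compound 3 in this assay, with no difference at the digits reported, which lies within the scatter. Compound 2 stands higher than compound 1 by a gap beyond the scatter. Among the compounds with values here, none of these three pairs differs in a single place, so no step between measured compounds can be read from them.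

Compound 4, `O=c1[nH]nc2n(c1=O)CCN2c1ccc(Cl)cc1`, is the compound still to be measured. It differs from compound 1 by chloro in place of hydrogen on an aromatic carbon.

The measured compounds offer no comparable change to lean on, so only a small step is expected from compound 1 to compound 4 in this assay: the estimated shift is a number 5 percentage points higher from compound 1 to compound 4 (within the scatter), upward if anything, and not clearly beyond the scatter. For compound 4 the expected value in this assay is 5%, with a range from 0% to 20%.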

Compound 4, a percentage reported as inhibition, at one concentration (the size of the read-out at that concentration, not a potency): 1%
Compound 4: the middle estimate sits 4 percentage points above what was measured; measured number inside the range.
By their numbers in this assay, from the lowest: compounds 1, 3 and 4 (each within the scatter of the next); then compound 2.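

Chloro in place of hydrogen on an aromatic carbon, para to a large group, gives a number 1 percentage points higher from compound 1 to compound 4 (within the scatter) in this comparison (this assay). Within the data shown here, this is the first single-place step, and it shows that this change at this position does not move the read-out beyond the scatter at the concentration tested. Nothing at hand bears on the reason for this result.

From the compounds shown here alone, it remains open whether a different group at the same position, such as an amine, a carboxylic acid or a longer alkyl chain, would separate from compound 1 by more than the scatter. Also open, going by these compounds, is whether chloro on another aromatic carbon of compound 1 would behave as it does in compound 4, as compound 3 differs from compound 1 in more than one place.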